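The compounds below may be only part of what the source reports. "The series", "measured", "known", "first", "only" and "open" are said of these compounds alone.

Compound 1 `CCC1C(=O)N(C)c2cnc(-n3ccc4cc(C(=O)NC(C)C)ccc43)nc2N1c1ccn(C)n1`: 8910 nM
Compound 2 `CCC1C(=O)N(C)c2cnc(-n3ccc4cc(F)ccc43)nc2N1c1ccn(C)n1`: 6070 nM
Compound 3 `CCCNC(=O)c1ccc2c(ccn2-c2ncc3c(n2)N(c2ccn(C)n2)C(CC)C(=O)N3C)c1`: 8270 nM

These values were measured in a functional assay on K562 cells (Homo sapiens) for antiproliferative activity, read by CCK-8 assay, with a stated time of 72 h; on this read-out higher numbers stand for weaker inhibition of growth and lower numbers for stronger inhibition of growth. Compound 3, at 8270 nM, lies within the scatter of both other compounds, so the three cannot be ranked. Compound 4 `CCCCNC(=O)c1ccc2c(ccn2-c2ncc3c(n2)N(c2ccn(C)n2)C(CC)C(=O)N3C)c1` differs from compound 3 by one change, (methyl in place of hydrogen on a saturated chain carbon, three bonds along the chain from an amide-type nitrogen). This is methyl in place of hydrogen on a saturated chain carbon, three bonds along the chain from an amide-type nitrogen, which turns propyl into butyl.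

Within the data shown here, two measured steps bear on this. The closest rearranges the same amide chain, giving a 1.1-fold lower number from compound 1 to compound 3 (0.03 log units; within the scatter). The larger swap of the whole group gives a 1.4-fold higher number from compound 2 to compound 3 (0.13 log units; within the scatter), and a 1.5-fold lower number from compound 1 to compound 2 (0.17 log units; within the scatter) points the same way. Among the measured compounds shown here, none of them leaves the scatter, although no measured step lengthens the chain. A step beyond the scatter is therefore not expected in this assay. The estimated step is a 1.0-fold lower number from compound 3 to compound 4 (0.01 log units; within the scatter). For compound 4 the expected value is 8000 nM, with an estimated range from 4500 nM to 14000 nM.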

Compound 4, concentration for 50% growth inhibition: 14100 nM
The estimate for compound 4 lay 1.8-fold (0.25 log units) below the measured number, and the stated range ends below it.
By their numbers in this assay, from the lowest: compounds 2, 3, 1 and 4 (each within the scatter of the next, the first and the last beyond it).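

In this assay, the step that turns propyl into butyl gives a 1.7-fold higher number from compound 3 to compound 4 (0.23 log units; within the scatter), and butyl in place of isopropyl on the amide-type nitrogen gives a 1.6-fold higher number from compound 1 to compound 4 (0.20 log units; within the scatter), so neither change to this amide chain leaves the scatter. Butylcarbamoyl in place of fluoro on the aromatic carbon gives a 2.3-fold higher number from compound 2 to compound 4 (0.37 log units; beyond the scatter), the first step here to leave the scatter, though only modestly, and compound 1 and compound 3 go against any general reading of amides versus fluoro, since their steps from compound 2 stay within the scatter. No available evidence explains this small separation.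

Going by these compounds, whether a pentyl or still longer chain would carry the number clearly beyond the scatter remains open. So does the effect of an amine or a carboxylic acid at the end of the chain.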